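This account rests on a few compounds, and the source may have more. Where it says the series, first, only, none or still open, it means among the compounds named here.

Compound 1 `CCN(CC)CCNC(=O)c1ccc(C(CC)(CC)c2ccc(OCC(O)C(C)(C)C)c(C)c2)n1CC` gives 6.54 nM in an assay on cells for agonist activity at vitamin D3 receptor (Homo sapiens), read by microscopy; on this read-out lower numbers stand for an effect already at smaller amounts and higher numbers for an effect only at larger amounts of compound.
Compound 2 `CCn1cc(C(CC)(CC)c2ccc(C#CC(O)(CC)CC)c(C)c2)cc1C(=O)NCC(=O)OC` gives 288 nM in this assay.

Of these two numbers compound 2 holds the higher one, and the gap to compound 1 lies beyond the scatter. Compound 3 `CCCCC(=O)c1cc(C(CC)(CC)c2ccc(C#CC(O)(CC)CC)c(C)c2)cn1CC` is not yet measured. It differs from compound 2 by butyl in place of ((methoxycarbonyl)methyl)amino on a carbonyl carbon. Among the compounds with values here, no step between measured compounds shows what this exchange does on its own, and compound 1 differs from both in several places at once. The step is therefore expected to be small, a 1.2-fold lower number from compound 2 to compound 3 (0.06 log units; within the scatter), and not beyond the scatter in either direction. Compound 3 is expected at 250 nM, within 60 nM to 1000 nM.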

Compound 3, half-maximal effective concentration: > 50 nM
Compound 3 gave a limit, no number (the forecaster's own chance of this, stated with the estimate: 5%); the middle value does not contradict the limit.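

In this assay compound 3 gives only a limit, > 50 nM, and not a number, so no step can be read between compound 2 and compound 3. On these data alone, what butyl in place of ((methoxycarbonyl)methyl)amino on a carbonyl carbon does on its own remains open.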